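Fluoro on the fused ring of a chromone diaryl urea

A few compounds are considered here, and "the series" means these few. Any claim that something is new, unique, unknown or untested is made for them only; others in the source may bear on it.

Measured compounds:
Compound 1, `O=C(Nc1cccc(Cl)c1)Nc1ccc(-c2cc(=O)c3ccccc3o2)c(Cl)c1`, 25400 nM
Compound 2, `CCc1ccc2oc(-c3ccc(NC(=O)Nc4cccc(Cl)c4)cc3Cl)cc(=O)c2c1`, 27900 nM

Of the compounds shown here, two have been measured in a functional assay on HCT-116 cells (Homo sapiens) for inhibition, read by MTT assay, with a stated time of 48 h; a higher number here means a weaker inhibitor, a lower number a stronger inhibitor. Compound 1 gives 25400 nM. Compound 2 gives 27900 nM. Compound 1 has the lowest of the two numbers, but the step of a 1.1-fold higher number from compound 1 to compound 2 (0.04 log units; within the scatter) lies within the scatter, so the two values cannot be told apart.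

Compound 3, `O=C(Nc1cccc(Cl)c1)Nc1ccc(-c2cc(=O)c3cc(F)ccc3o2)c(Cl)c1`, has not yet been measured in this assay. It differs from compound 1 in one place: fluoro in place of hydrogen on an aromatic carbon.

Within the data shown here, only one measured step bears on this change, namely a 1.1-fold higher number from compound 1 to compound 2 (0.04 log units; within the scatter), in which a substituent was likewise placed on an aromatic carbon of the fused ring system of the shared core, and the number did not move beyond the scatter. On that basis a step of no more than the scatter is expected from compound 1 to compound 3, with no preferred direction, as a 1.0-fold lower number from compound 1 to compound 3 (0.01 log units; within the scatter). Compound 3 is therefore estimated at 25000 nM, within a range of 12000 nM to 52000 nM.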

Compound 3, half-maximal inhibitory concentration: 24200 nM
For compound 3 the middle estimate is 1.0-fold (0.01 log units) above the measured one; low and high end bracket the measured number.
By their numbers in this assay, from the lowest: compounds 3, 1 and 2 (each within the scatter of the next).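

In this assay the change from hydrogen to fluoro on this aromatic carbon gives a 1.0-fold lower number from compound 1 to compound 3 (0.02 log units; within the scatter) and the change from ethyl to fluoro on the same carbon gives a 1.2-fold lower number from compound 2 to compound 3 (0.06 log units; within the scatter) so that neither step lies beyond the scatter. Where the earlier compounds offered a single comparison, hydrogen against ethyl, there are now three groups on this one carbon of the fused system of two rings, and all three pairs lie within the scatter of each other, with no compound going against this. The assay therefore does not separate hydrogen, ethyl and fluoro at this place in the shared core, and no evidence is at hand that would explain this result.

The three compounds leave open whether any other group on this carbon, such as an amine, a carboxylic acid or a longer chain, would move the number beyond the scatter. They also leave open whether fluoro on another carbon of the same ring would behave as it does here.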